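A methoxypyridine replaces a fluoromethoxyphenyl: expected cytotoxicity

This account rests on a few compounds, and the source may have more. Where it says the series, first, only, none or still open, it means among the compounds named here.

Compound 1 `N#Cc1ccc(-c2ccc(CO[C@@H]3COc4nc([N+](=O)[O-])cn4C3)s2)cc1` and compound 2 `COc1ccc(-c2ccc(CO[C@@H]3COc4nc([N+](=O)[O-])cn4C3)s2)cc1F` share one core and differ only in the aryl group attached to the five-membered aromatic ring with 1 sulfur. In an ADME assay on Vero cells (Chlorocebus sabaeus) for cytotoxicity, with a stated time of 72 h (on this read-out lower numbers stand for stronger inhibition and higher numbers for weaker inhibition), compound 1 gives only a limit of > 128000 nM. In this assay compound 2 also gives only a limit, > 128000 nM. The step that the two limits leave unreadable from compound 1 to compound 2 is therefore unreadable. Among the measured compounds shown here, compound 2 thus stands at the edge of what the assay reports, and the limit of > 128000 nM in this assay, at which 2 of the 2 values shown sit, shows that no value so far lies inside the measurable window.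

Compound 3 `COc1ccc(-c2ccc(CO[C@@H]3COc4nc([N+](=O)[O-])cn4C3)s2)cn1` differs from compound 2 by 6-methoxypyridin-3-yl in place of 3-fluoro-4-methoxyphenyl on an aromatic carbon. For the measured compounds named here, the one measured step at this position, a step that the two limits leave unreadable from compound 1 to compound 2, bears on the change but carries no readable size, since both of its ends are limits. Going by the values given here, no measured step points to a movement in either direction, so the expectation for the step from compound 2 to compound 3 is none beyond the scatter, a step that the limit leaves unreadable from compound 2 to compound 3. Compound 3 is accordingly estimated at 150000 nM in this assay, with a range from 90000 nM to 300000 nM, and most likely reported again only as a limit.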

Compound 3, half-maximal inhibitory concentration: > 128000 nM
Compound 3: no number, only a limit (the forecaster's own chance of this, stated with the estimate: 85%); the middle value does not contradict the limit.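

Among the compounds shown here, compound 3 gives only a limit in this assay, > 128000 nM, so no step from compound 1 or compound 2 to compound 3 can be read. The compounds shown leave open how these three aryl groups compare on the shared core, because no value lies inside the measurable window: the limit of > 128000 nM in this assay, at which 3 of the 3 values shown sit.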